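The source may hold more compounds than are shown below. What is called first, only, known or untested is meant among the compounds shown, and "the series" means these compounds.

Measured compounds in a functional assay on DU-145 cells (Homo sapiens) for inhibition, read by trypan blue exclusion, with a stated time of 96 h; on this read-out lower numbers stand for stronger inhibition of growth and higher numbers for weaker inhibition of growth:
Compound 1 `O=C(/C(=C\c1ccc(O)cc1)SCc1ccc(F)cc1)c1ccc(Cl)cc1` gives 25000 nM.
Compound 2 `Cc1ccc(/C=C(/SCc2ccc(F)cc2)C(=O)c2ccc(Cl)cc2)s1` gives only the assay limit > 100000 nM.

Compound 2 thus stands at the limit of this assay with no number of its own (the limit of > 100000 nM in this assay, at which 1 of the 2 values shown sits). Compound 3 `O=C(/C(=C\c1ccc(Br)cc1)SCc1ccc(F)cc1)c1ccc(Cl)cc1` differs from it by 4-bromophenyl in place of 5-methylthiophen-2-yl on a double-bonded chain carbon bound to a double-bonded chain carbon. Among the measured compounds shown here, the one measured step at this place is an at least 4.0-fold higher number from compound 1 to compound 2 (0.60 log units; beyond the scatter), which ran the other way, from 4-hydroxyphenyl to 5-methylthiophen-2-yl. Going back to a phenyl, here 4-bromophenyl, is therefore expected to lower the number in this assay, giving an at least 2.5-fold lower number from compound 2 to compound 3 (0.39 log units; beyond the scatter). Compound 3 is estimated at 40000 nM, between 10000 nM and 100000 nM.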

Compound 3, concentration for 50% growth inhibition: 9000 nM
For compound 3 the middle estimate is 4.4-fold (0.65 log units) above the measured one; the whole stated range lies above it.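

In this assay, among the compounds shown here, the earlier compounds showed only a loss at this place, whereas 4-bromophenyl in place of 5-methylthiophen-2-yl gives an at least 11-fold lower number from compound 2 to compound 3 (1.04 log units; beyond the scatter). The size of that step is open-ended, as compound 2 has no number of its own: the limit of > 100000 nM in this assay, at which 1 of the 3 values shown sits. The phenyl alone does not set the number, since bromo in place of hydroxy on an aromatic carbon gives a 2.8-fold lower number from compound 1 to compound 3 (0.44 log units; beyond the scatter).

Going by these compounds, what an amine or a carboxylic acid on that phenyl would do to the number stays open, as does the effect of a phenyl carrying neither bromo nor hydroxy.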